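The source may report more compounds than this note shows. Statements on the series, on what has been measured and on what is new or still open speak of the compounds shown alone.

Compound 1, with the structure `Cc1ccc(-n2cc(-c3ccccc3NS(=O)(=O)c3c[nH]c(=O)[nH]c3=O)nn2)cc1`, is the reference point of this small set. In a functional assay on SGC-7901 cells (Homo sapiens) for antiproliferative activity, read by MTT assay, with a stated time of 24 h (on this read-out lower numbers stand for stronger inhibition and higher numbers for weaker inhibition), compound 1 gives 6390 nM. Compound 2, with the structure `O=c1[nH]cc(S(=O)(=O)Nc2ccccc2-c2cn(-c3ccccc3F)nn2)c(=O)[nH]1`, carries the change (2-fluorophenyl in place of 4-methylphenyl on an aromatic nitrogen), and in this assay compound 2 gives 10800 nM. The step for this exchange is a 1.7-fold higher number from compound 1 to compound 2 (0.23 log units; within the scatter), so the two numbers are not separated by more than the usual scatter of the method.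

Compound 3, with the structure `Cc1ccc(-n2cc(-c3ccc(NS(=O)(=O)c4c[nH]c(=O)[nH]c4=O)cc3)nn2)cc1`, is built from the same atoms as compound 1 but joined differently; the difference between the two cores is not broken down here. In this assay compound 3 gives 8350 nM, a number that, set beside those of compound 1 and compound 2, stays within the scatter of both.

Compound 4, with the structure `O=c1[nH]cc(S(=O)(=O)Nc2ccc(-c3cn(-c4ccccc4F)nn3)cc2)c(=O)[nH]1`, has not yet been measured. It relates to compound 3 through (2-fluorophenyl in place of 4-methylphenyl on an aromatic nitrogen), which is the same change, at the same place, that separates compound 2 from compound 1. Among the compounds with values here, from compound 3 to compound 4 the expected step is a 1.6-fold higher number from compound 3 to compound 4 (0.19 log units; within the scatter), resting on the single measured example of this change, a 1.7-fold higher number from compound 1 to compound 2 (0.23 log units; within the scatter), applied to the value of compound 3, 8350 nM. On that basis compound 4 is expected to give about 13000 nM in this assay, with a plausible range from 6500 nM to 26000 nM.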

Compound 4, half-maximal inhibitory concentration: 7270 nM
Compound 4: the middle estimate sits 1.8-fold (0.25 log units) above what was measured, within the range that was stated.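

In this assay, the exchange of 4-methylphenyl for 2-fluorophenyl on the aromatic nitrogen gives a 1.1-fold lower number from compound 3 to compound 4 (0.06 log units; within the scatter), so on this core, as on the core of compound 1, the method does not separate the two numbers. The two steps are printed in opposite directions, but that difference carries no weight, as the gap between them is also small: the same change on two cores in this assay, a 1.7-fold higher number (0.23 log units; within the scatter) from compound 1 to compound 2 and a 1.1-fold lower number (0.06 log units; within the scatter) from compound 3 to compound 4, 1.9-fold (0.29 log units) apart, within the scatter of two such steps. This shows that the exchange behaved alike on both cores, in that neither pair gave a step beyond the scatter; it does not show that the exchange has no effect, nor that an effect of a fixed size carries from one core to the other, as a step that cannot be told from the scatter gives no size to carry over, and two pairs are a narrow basis for any rule in this series.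

The compounds shown leave open whether a different group on the same aromatic nitrogen, such as a phenyl bearing an amine or a carboxylic acid, or a longer alkyl chain, would give numbers that stand clear of the scatter. They also leave open whether any such group would then behave alike on the two cores.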